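Working notes: from compound 3 to compound 4

A few compounds are considered here, and "the series" means these few. Any claim that something is new, unique, unknown or untested is made for them only; others in the source may bear on it.

Measured in a physicochemical assay, read by HPLC, in phosphate buffer, with a stated time of 8 days, at pH 7.4; on this read-out lower numbers stand for a less stable compound and higher numbers for a more stable compound:
compound 1 `CCOC(=O)c1ccc(/N=N/N(C)C(=O)CCCCc2ccc(O)cc2)cc1` 100%
compound 2 `CC(=O)c1ccc(/N=N/N(C)C(=O)CCCCc2ccc(O)cc2)cc1` 100%
compound 3 `Cc1ccc(/N=N/N(C)C(=O)CCCCc2ccc(O)cc2)cc1` 100%

In this assay compound 3 gives 100% and stands level with compound 1 and compound 2. The next compound is compound 4 `CN(/N=N/c1ccc(Br)cc1)C(=O)CCCCc1ccc(O)cc1`, with bromo in place of methyl on an aromatic carbon. This is bromo in place of methyl on an aromatic carbon, para to a large group. Two measured steps replace a group on an aromatic carbon: no change at the digits printed from compound 1 to compound 3 (within the scatter) and no change at the digits printed from compound 2 to compound 3 (within the scatter). A third, no change at the digits printed from compound 1 to compound 2 (within the scatter), is equally small. For the measured compounds named here, no bromo compound has been measured yet, so this expectation rests on those three steps alone. No step beyond the scatter is expected, and the expected step is a number 1 percentage points lower from compound 3 to compound 4 (within the scatter). For compound 4 the estimated value is 99%, within an expected range of 90% to 100%.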

Compound 4, percent of the compound remaining: 100%
Beside the measured number, compound 4's estimate is 1 percentage points below it, within the range that was stated.
By their numbers in this assay, from the lowest: compounds 1, 2, 3 and 4 (each within the scatter of the next).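

In this assay, bromo on the aromatic carbon para to a large group reads the same as the three earlier groups, with no change at the digits printed from compound 3 to compound 4 (within the scatter) and no change at the digits printed from compound 2 to compound 4 (within the scatter) and likewise no change at the digits printed from compound 1 to compound 4 (within the scatter) on the same read-out. A halogen therefore joins methyl, acetyl and ethoxycarbonyl at this position with no separation among the four compounds. Still open, as far as these compounds go, is how an amine or a carboxylic acid would read here, and whether any group at this position lowers the percentage remaining. No available evidence bears on why the four compounds read alike.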